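The compounds below may be only part of what the source reports. "The series", "measured", "known", "first", "only" and "open" are said of these compounds alone.

Measured in a functional assay on A-375 cells (Homo sapiens) for cytotoxicity, read by MTT assay, with a stated time of 72 h (a lower number here means a stronger inhibitor, a higher number a weaker inhibitor), so far:
- compound 1 `O=C1c2c[n+]([O-])c3ccccc3c2C(=O)c2c1c1ccccc1n2CCN1CCCC1` gives 430 nM here
- compound 2 `CN(C)CCCCn1c2c(c3ccccc31)C(=O)c1c[n+]([O-])c3ccccc3c1C2=O` gives 470 nM here

Compound 2 cannot be separated from compound 1, since their values lie within the scatter of each other. Compound 3 `O=C1c2c[n+]([O-])c3ccccc3c2C(=O)c2c1c1ccccc1n2CCCN1CCC(O)CC1` differs from compound 2 by 4-hydroxypiperidin-1-yl in place of (dimethylamino)methyl on a saturated chain carbon, three bonds along the chain from an aromatic nitrogen on a saturated chain carbon, three bonds along the chain from an aromatic nitrogen. Among the measured compounds shown here, the only measured step that bears on this, a 1.1-fold higher number from compound 1 to compound 2 (0.04 log units; within the scatter), also exchanged one amine group for another and stayed within the scatter. For the measured compounds named here, no step beyond the scatter is therefore expected in this assay, although no measured compound carries 4-hydroxypiperidin-1-yl. The estimated step is a 1.2-fold higher number from compound 2 to compound 3 (0.07 log units; within the scatter) in this measure. Compound 3 is expected at 550 nM, with an estimated range from 220 nM to 1400 nM here.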

Compound 3, half-maximal inhibitory concentration: 240 nM
Estimate against measurement, compound 3: 2.3-fold (0.36 log units) above; low and high end bracket the measured number.
By their numbers in this assay, from the lowest: compounds 3, 1 and 2 (each within the scatter of the next).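

In this assay, a chain ending in 4-hydroxypiperidin-1-yl, with its ring and hydrogen-bond donor, gives a 2.0-fold lower number from compound 2 to compound 3 (0.29 log units; within the scatter) and a 1.8-fold lower number from compound 1 to compound 3 (0.25 log units; within the scatter). This chain position has therefore carried three different amine end groups with no separable difference in this assay. No measurement shown offers an explanation for this result.

Chain length and amine end group change together here, so neither effect can be read alone. From the compounds shown here alone, a carboxylic acid at the chain end, or a chain with no amine, remains open.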